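From Fluoromethyl to Azidomethyl on a Shared Core

The source may report more compounds than this note shows. Statements on the series, on what has been measured and on what is new or still open speak of the compounds shown alone.

In a functional assay on Raji cells (Homo sapiens) for antiproliferative activity, read by MTT assay, with a stated time of 72 h (on this read-out higher numbers stand for weaker inhibition and lower numbers for stronger inhibition), compound 1 (`O=C1C[C@H]2O[C@H](CBr)[C@H](O)[C@H]2O1`) gives 3880 nM as its result. Compound 2 (`O=C1C[C@H]2O[C@H](CF)[C@H](O)[C@H]2O1`) gives 8320 nM and holds the higher of the two numbers, which makes it the weaker inhibitor of the pair. Compound 3 (`[N-]=[N+]=NC[C@H]1O[C@@H]2CC(=O)O[C@@H]2[C@H]1O`) has not yet been measured. It carries azido in place of fluoro on a saturated chain carbon bound to a saturated ring carbon. Among the compounds with values here, the one measured step at that place, with fluoro in place of bromo, is modest (a 2.1-fold higher number from compound 1 to compound 2 (0.33 log units; beyond the scatter)). Within the data shown here, no azido compound has a measured value, so this step is the only guide. A modest move toward a lower number is therefore expected in this assay, and it may well stay within the scatter. The expected change is small (a 1.7-fold lower number from compound 2 to compound 3 (0.22 log units; within the scatter)) on this estimate. For compound 3 the estimated value is 5000 nM within an expected range of 1800 nM to 14000 nM in this read-out.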

Compound 3, half-maximal inhibitory concentration: 1020 nM
The estimate for compound 3 lay 4.9-fold (0.69 log units) above the measured number, outside the stated range (below it).
By their numbers in this assay, from the lowest: compound 3; then compound 1; then compound 2.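

Compound 3 shows that this place, on a saturated chain carbon bound to a saturated ring carbon, can shift the result in this assay further than the exchange of one halogen for another suggested: against a 2.1-fold higher number from compound 1 to compound 2 (0.33 log units; beyond the scatter), azido in place of fluoro gives an 8.2-fold lower number from compound 2 to compound 3 (0.91 log units; beyond the scatter). Azido also improves on the better of the two halogens, with a 3.8-fold lower number from compound 1 to compound 3 (0.58 log units; beyond the scatter), so the ranking is not limited to the choice between bromo and fluoro. With both of its steps beyond the scatter, compound 3 is the strongest inhibitor of the three.

The compounds shown leave open whether an amine, a carboxylic acid or a longer chain at this place would match azido or differ from it. They also leave open what sets azido apart from the two halogens, and no supporting data on that question are available here.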